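A few compounds are considered here, and "the series" means these few. Any claim that something is new, unique, unknown or untested is made for them only; others in the source may bear on it.

Measured compounds:
- compound 1, `NNC(=O)Cc1cc(=O)oc2cc(OCc3cccc(Cl)c3)ccc12`: 90 nM
- compound 2, `CN(Cc1ccccc1)Cc1cc(=O)oc2cc(OCc3cccc(Cl)c3)ccc12`: 8000 nM
- compound 3, `NCc1cc(=O)oc2cc(OCc3ccccc3)ccc12`: 21 nM

In an assay for inhibition of Amine oxidase [flavin-containing] B (Rattus norvegicus) (a lower number here means a stronger inhibitor, a higher number a weaker inhibitor), compound 3 gives the lowest of the three numbers. Its nearest neighbour is compound 1, whose value in this assay is 90 nM, beyond the scatter from compound 3; furthest away is compound 2, with 8000 nM in this assay. Going by the values given here, the only step between measured compounds that differ in one place, an 89-fold higher number from compound 1 to compound 2 (1.95 log units; beyond the scatter), concerns the group on the saturated chain carbon and not the ether-linked ring.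

Compound 4, `NCc1cc(=O)oc2cc(OCc3cccc(Cl)c3)ccc12`, differs from compound 3 in one place: chloro in place of hydrogen on an aromatic carbon. Among the compounds with values here, none of the measured steps bears on this change; compound 1 and compound 2 both carry the chloro-substituted ring already, so they tell nothing about adding it. The expected step of a 1.2-fold lower number from compound 3 to compound 4 (0.07 log units; within the scatter) is therefore small, within the scatter, with no clear direction. Compound 4 is expected to give about 18 nM in this assay, within a range from 6 nM to 55 nM.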

Compound 4, half-maximal inhibitory concentration: 15 nM
Compound 4: the middle estimate sits 1.2-fold (0.08 log units) above what was measured; the measured number falls inside the stated range.
By their numbers in this assay, from the lowest: compounds 4 and 3 (each within the scatter of the next); then compound 1; then compound 2.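

With amino on the saturated chain carbon, a 1.4-fold lower number from compound 3 to compound 4 (0.15 log units; within the scatter) shows that in this assay phenyl and 3-chlorophenyl cannot be told apart, so chloro in place of hydrogen on this aromatic carbon leaves no measurable mark in this setting. Compound 4 also gives the earlier chloro-bearing compounds a partner that differs from them in one place, which places amino against the other two groups on the same ring: a 6.0-fold lower number from compound 1 to compound 4 (0.78 log units; beyond the scatter) is a modest step for aminocarbamoyl, while a 530-fold lower number from compound 2 to compound 4 (2.73 log units; beyond the scatter) is a large one for benzyl(methyl)amino, and both lie beyond the scatter. The change of group on the saturated chain carbon therefore counts for far more here than the chloro, though no accompanying evidence bears on why these numbers fall as they do.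

On these data alone, it remains open whether phenyl and 3-chlorophenyl would also match when aminocarbamoyl or benzyl(methyl)amino occupies the chain, and whether fluoro or methoxy in place of the chloro would do the same. Equally open, as far as these compounds go, is how a methylamino group or a carboxylic acid on the saturated chain carbon would compare with amino.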